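The source may report more compounds than this note shows. Statements on the series, on what has been measured and on what is new or still open speak of the compounds shown alone.

Working notes on the series. Three compounds carry a shared core with a sulfur-linked side chain and differ only in what hangs from that chain: compound 1 `Brc1cccc(CSc2nnc(-c3ccncc3)n2-c2ccccc2)c1`, compound 2 `Fc1cccc(F)c1CSc1nnc(-c2ccncc2)n1-c1ccccc1` and compound 3 `COc1ccc(/C=N/NC(=O)CSc2nnc(-c3ccncc3)n2-c2ccccc2)cc1`. In a functional assay on HepG2 cells (Homo sapiens) for inhibition, read by MTT assay, with a stated time of 48 h (on this read-out lower numbers stand for stronger inhibition and higher numbers for weaker inhibition), compound 1 gives 7040 nM. Compound 2 gives only a limit, > 50000 nM. Within the data shown here, the one single-point step among the measured compounds is an at least 7.1-fold higher number from compound 1 to compound 2 (0.85 log units; beyond the scatter); that compound 2 sits at the limit is recorded by the limit of > 50000 nM in this assay, at which 1 of the 3 values shown sits. Compound 3 gives 27100 nM in this assay, the higher of the two numbers, with compound 1 the nearest and lower, beyond the scatter.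

Compound 4 `O=C(CSc1nnc(-c2ccncc2)n1-c1ccccc1)N/N=C/c1ccc(O)cc1` is not yet measured. It differs from compound 3 by hydrogen in place of methyl on an oxygen on an aromatic ring. Among the measured compounds shown here, no measured step touches that position: the step from compound 1 to compound 2 changes the aryl ring on the saturated chain carbon bound to sulfur, and the gap between compound 1 and compound 3 changes the whole side chain. The expectation is therefore a step no larger than the scatter, a 1.1-fold lower number from compound 3 to compound 4 (0.04 log units; within the scatter), in this assay. For compound 4 the estimate is 25000 nM, expected to fall between 8000 nM and 70000 nM.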

Compound 4, half-maximal inhibitory concentration: > 50000 nM
Compound 4: a limit, no number; the forecaster's own chance of this, stated with the estimate: 25%; at least 2.0-fold (0.30 log units) between middle value and limit.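

Among these compounds, the change from methoxy to hydroxy is the only measured step at this position, and in this assay it reads as an at least 1.8-fold higher number from compound 3 to compound 4 (0.26 log units; that floor lies within the scatter). The step is only a floor, so the data do not distinguish a difference within the scatter from a larger loss; they show only that removing the methyl on the oxygen on the aromatic ring did not bring the number below that of compound 3. Compound 4 gives > 50000 nM, which is a limit and not a number, and compound 2 sits at the same limit: the limit of > 50000 nM in this assay, at which 2 of the 4 values shown sit.

On these data alone, whether an ethyl group on that oxygen, or an amine or a carboxylic acid in place of the methoxy on the aromatic ring, would move the number in either direction remains open. With a single step at this position, and that one bounded only from one side, no trend across groups at this position can be drawn from the compounds shown.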